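Hydroxy added beside the nitro group on the curcumin-like chalcone

The compounds below may be only part of what the source reports. "The series", "measured", "known", "first", "only" and "open" are said of these compounds alone.

Measured compounds:
compound 1 `COc1cc(/C=C/C(=O)/C=C/C2=C(C)CCCC2(C)C)ccc1O`: 9500 nM
compound 2 `CC1=C(/C=C/C(=O)/C=C/c2cccc(C(F)(F)F)c2)C(C)(C)CCC1`: 2800 nM
compound 3 `CC1=C(/C=C/C(=O)/C=C/c2cccc([N+](=O)[O-])c2)C(C)(C)CCC1`: 2700 nM

In a functional assay on LNCaP cells (Homo sapiens) for cytotoxicity, read by MTT assay, with a stated time of 72 h (on this read-out lower numbers stand for stronger inhibition and higher numbers for weaker inhibition), compound 3 gives 2700 nM. Compound 2, which differs from it only in the group on the aromatic ring, gives 2800 nM; the step of a 1.0-fold lower number from compound 2 to compound 3 (0.02 log units; within the scatter) is within the scatter, so the two cannot be ordered. Among the compounds with values here, compound 1, which carries a hydroxy and a methoxy on its ring instead, gives 9500 nM, and its number lies beyond the scatter from that of compound 3; no single-point step links these two.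

Compound 4 `CC1=C(/C=C/C(=O)/C=C/c2ccc(O)c([N+](=O)[O-])c2)C(C)(C)CCC1` has not been measured. It differs from compound 3 in one place: hydroxy in place of hydrogen on an aromatic carbon. Within the data shown here, no measured step isolates a hydroxy on this ring. Among the measured compounds shown here, the only step on the ring, from trifluoromethyl to nitro, was flat, and the only measured compound bearing a hydroxy, compound 1, gives a higher number than compound 3, though it also differs in a second place. Compound 4 is therefore expected to give a somewhat higher number, a 1.5-fold higher number from compound 3 to compound 4 (0.17 log units; within the scatter), with an estimate of 4000 nM and a range of 1500 nM to 11000 nM.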

Compound 4, half-maximal inhibitory concentration: 26800 nM
The estimate for compound 4 lay 6.7-fold (0.83 log units) below the measured number; measured number above the stated range.
By their numbers in this assay, from the lowest: compounds 3 and 2 (each within the scatter of the next); then compound 1; then compound 4.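

Hydroxy on this aromatic carbon, ortho to a nitro group and para to a large group, is the first change on the ring that clearly moves the number in this assay with a 9.9-fold higher number from compound 3 to compound 4 (1.00 log units; beyond the scatter) as its size, whereas the earlier swap of trifluoromethyl for nitro stayed flat. With a hydroxy on the ring of both compounds, nitro in place of methoxy also raises the number, with a 2.8-fold higher number from compound 1 to compound 4 (0.45 log units; beyond the scatter) as the step. So the number reached with a ring hydroxy depends on the group that accompanies it, and nothing here bears on why the number rises at this place.

On these data alone, whether the rise belongs to the hydroxy alone or to its pairing with nitro stays open. So does whether an amine or a carboxylic acid at this place would keep the number of compound 3 or push it up as far as hydroxy does.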